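The source may report more compounds than this note shows. Statements on the series, on what has been measured and on what is new or still open speak of the compounds shown alone.

Compound 1 `Cc1cc(-c2ccc3[nH]c(=O)nc(-c4ccccc4)c3c2)ccn1` is the starting point of this comparison. In an ADME assay on THP-1 cells (Homo sapiens) for cytotoxicity, read by MTT assay, with a stated time of 72 h (a lower number here means that less compound is needed, a higher number that more compound is needed for the effect), compound 1 gives only a limit of the assay, > 50000 nM. Two close relatives share that outcome. Compound 2 `O=c1nc(-c2ccccc2)c2cc(-c3cccc(F)c3)ccc2[nH]1` also gives in this assay a limit, > 50000 nM. Compound 3 `O=c1nc(-c2ccccc2)c2cc(-c3ccc(F)cc3)ccc2[nH]1` likewise gives in this assay a limit, > 50000 nM. Because all three sit at the limit of > 50000 nM in this assay, at which 3 of the 3 values shown sit, no size can be read for the step that the two limits leave unreadable from compound 1 to compound 2, nor for a step that the two limits leave unreadable from compound 1 to compound 3, nor for a step that the two limits leave unreadable from compound 2 to compound 3; each only shows that exchanging the outer ring left the outcome at the limit.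

Compound 4 `N#Cc1ccc(-c2ccc3[nH]c(=O)nc(-c4ccccc4)c3c2)cc1` is not yet measured. It differs from compound 1 in one place: 4-cyanophenyl in place of 2-methylpyridin-4-yl on an aromatic carbon. The three measured steps bear on this change in that every outer-ring replacement so far kept the read-out at the limit, but none has a readable size, so no step beyond the scatter in this assay is expected in either direction. Compound 4 is therefore estimated at 50000 nM, within a range from 20000 nM to 100000 nM. The expected step is a number no higher from compound 1 to compound 4 (the limit leaves the size open), which would most likely leave the result at the limit once more.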

Compound 4, half-maximal effective concentration: > 50000 nM
Compound 4 ended at the assay's limit (the forecaster's own chance of this, stated with the estimate: 85%); the middle value lies on the limit itself.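

No size can be read for any step from compounds 1, 2 or 3 to compound 4, because in this assay all four give only a limit: the limit of > 50000 nM in this assay, at which 4 of the 4 values shown sit. The compounds shown leave open whether these outer rings differ at all in cytotoxicity, and which change to the shared core would bring a readable value.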